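Taking the acetyl group off compound 2

A few compounds are considered here, and "the series" means these few. Any claim that something is new, unique, unknown or untested is made for them only; others in the source may bear on it.

Compound 1 (`CC(=O)O[C@H]1[C@@H](COC(=O)c2ccccc2)C[C@]2(OC(=O)/C=C/c3ccccc3)C(=O)/C(C)=C/[C@@H]3[C@H](CC[C@@]4(C)O[C@@H]4[C@@H]12)C3(C)C`) gives 7.9
Compound 2 (`CC(=O)OC[C@H]1C[C@]2(OC(=O)/C=C/c3ccccc3)C(=O)/C(C)=C/[C@@H]3[C@H](CC[C@@]4(C)O[C@@H]4[C@H]2[C@H]1O)C3(C)C`) gives 5.5

Both values come from a physicochemical assay for lipophilicity; a lower number here means a more polar compound, a higher number a more lipophilic compound. Compound 2 stands lower (5.5) and compound 1 higher (7.9), a gap beyond the scatter. Compound 3 (`C/C1=C\[C@@H]2[C@H](CC[C@@]3(C)O[C@@H]3[C@H]3[C@@H](O)[C@@H](CO)C[C@]3(OC(=O)/C=C/c3ccccc3)C1=O)C2(C)C`) differs from compound 2 in one place (hydrogen in place of acetyl on an oxygen on a saturated carbon): hydrogen in place of acetyl on an oxygen on a saturated carbon, so acetoxymethyl becomes hydroxymethyl. For the measured compounds named here, no measured pair shows this change alone, so the expectation is only a judgement: a moderate downward step in this assay beyond the scatter. The expected step runs (a number 0.80 log units lower from compound 2 to compound 3 (beyond the scatter)). For compound 3 the estimated value is 4.7 (range 4.2 to 5.2).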

Compound 3, partition coefficient: 4.8
Compound 3: middle estimate off by 0.10 log units, on the low side, and the stated range covers the measured number.
By their numbers in this assay, from the lowest: compound 3; then compound 2; then compound 1.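

For the compounds shown here, this is the first pair differing in one place only, so acetoxymethyl to hydroxymethyl can now be read on its own in this assay, with a step of a number 0.70 log units lower from compound 2 to compound 3 (beyond the scatter) in this single comparison. Hydrogen in place of acetyl on this oxygen therefore moves the number beyond the scatter. No measurement here explains the size of this step. From the compounds shown here alone, what an amine or a carboxylic acid at this place would give remains open. So does whether the same change elsewhere on the shared core would give a similar step.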